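This account rests on a few compounds, and the source may have more. Where it says the series, first, only, none or still open, it means among the compounds named here.

Compound 1 `Cc1nc(-c2ccccc2)sc1COc1ccc(OCC(=O)O)c(F)c1` gives 374 nM in an assay on CHO cells for agonist activity at Free fatty acid receptor 1 (Homo sapiens), read by FLIPR; a lower number here means that less compound is needed, a higher number that more compound is needed for the effect. Compound 2 `Cc1nc(-c2cccc(F)c2)sc1COc1ccc(OCC(=O)O)c(F)c1` gives 185 nM in this assay. Compound 3 `Cc1nc(-c2ccccc2)sc1COc1ccc2c(c1)OCC2CC(=O)O` gives 102 nM in this assay.

Compound 2 differs from compound 1 in one place: fluoro in place of hydrogen on an aromatic carbon This change produced a 2.0-fold lower number from compound 1 to compound 2 (0.31 log units; beyond the scatter). The difference between the cores of compound 1 and compound 3 is not broken down here. Compound 3 has the lowest number of the three, though its gap to compound 2 lies within the scatter.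

Compound 4 `Cc1nc(-c2ccc(F)cc2)sc1COc1ccc2c(c1)OCC2CC(=O)O` has not yet been measured. It differs from compound 3 by the same kind of change: fluoro in place of hydrogen on an aromatic carbon The surroundings are not identical, since the fluoro in compound 2 sits meta to a large group while in compound 4 it sits para to a large group. In this assay, among the compounds with values here, a step of similar size is expected for compound 4, a 1.6-fold lower number from compound 3 to compound 4 (0.20 log units; within the scatter), because the only measured example of this kind of change gave a 2.0-fold lower number from compound 1 to compound 2 (0.31 log units; beyond the scatter). Compound 4 is therefore estimated at 65 nM, most likely between 30 nM and 200 nM.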

Compound 4, half-maximal effective concentration: 79 nM
Estimate against measurement, compound 4: 1.2-fold (0.08 log units) below; measured number inside the range.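

In this assay, going from phenyl to 4-fluorophenyl gives a 1.3-fold lower number from compound 3 to compound 4 (0.11 log units; within the scatter), a step that cannot be told apart from no change on this core. The two fluoro steps do not differ by more than the scatter allows, and the change carries across the two cores without a visible difference: the same change on two cores in this assay, a 2.0-fold lower number (0.31 log units; beyond the scatter) from compound 1 to compound 2 and a 1.3-fold lower number (0.11 log units; within the scatter) from compound 3 to compound 4, 1.6-fold (0.19 log units) apart, within the scatter of two such steps. Within the data shown here, this does not prove that the effect is the same on both cores: there are only two steps, one lies within the scatter, and the fluoro sits at a different ring position in each pair.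

The compounds shown leave open how fluoro at other positions on this ring would behave on the core of compound 3. They also leave open what a chloro or methoxy group in its place would do.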